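Methoxy in place of hydrogen on the phenyl of compound 2

The source may hold more compounds than are shown below. What is called first, only, known or untested is meant among the compounds shown, and "the series" means these compounds.

Measured compounds:
compound 1 `O=C(Cn1cc(COc2ccc3c(c2)CCC3)nn1)Nc1ccccc1Cl` — "not determined" (no result reported) in an ADME assay on HEK293 cells (Homo sapiens) for inhibition, read by MTT assay, with a stated time of 48 h, tested at 25 uM; on this read-out lower numbers stand for less inhibition and higher numbers for more inhibition at the one concentration tested (going by the name of the read-out)
compound 2 `c1ccc(-n2cc(COc3ccc4c(c3)CCC4)nn2)cc1` — 23.4%
compound 3 `Cc1cc(C)c(-n2cc(COc3ccc4c(c3)CCC4)nn2)c(C)c1` — 16.6%

Three compounds share one core, and two of them carry a number in this assay. Compound 2 gives 23.4% and stands highest of the two numbers; compound 3, with three methyl groups on its aromatic ring, gives 16.6%, a result only a little lower and within the scatter of compound 2, so the two cannot be ordered. For the measured compounds named here, compound 1 gives "not determined" (no result reported) in this assay, and no step between measured compounds is available.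

Compound 4 `COc1ccc(-n2cc(COc3ccc4c(c3)CCC4)nn2)cc1` differs from compound 2 in one place: methoxy in place of hydrogen on an aromatic carbon. The phenyl of compound 2 becomes a 4-methoxyphenyl in compound 4, with the new group sitting on an aromatic carbon of a six-membered aromatic ring of carbon only, para to a large group.

Nothing in the measured pair argues for a large move either way, since the only other substitution on that ring, in compound 3, stayed within the scatter. Compound 4 is therefore expected to sit close to compound 2, with a step from compound 2 to compound 4 of a number 1.4 percentage points lower from compound 2 to compound 4 (within the scatter) that should not exceed the scatter. For compound 4 an inhibition of 22% is estimated, expected to fall between 8% and 38%.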

Compound 4, a percentage reported as inhibition, at one concentration (the size of the read-out at that concentration, not a potency): 21.1%
The estimate for compound 4 lay 0.9 percentage points above the measured number, and the stated range covers the measured number.
By their numbers in this assay, from the lowest: compounds 3, 4 and 2 (each within the scatter of the next).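

In this assay, for the compounds shown here, the replacement of hydrogen by methoxy on an aromatic carbon, para to a large group, gives the first step between compounds that differ in one place: a number 2.3 percentage points lower from compound 2 to compound 4 (within the scatter). The earlier numbers could not show this, since compound 2 and compound 3 differ in more than one place and so could not isolate the effect of a single group on this ring. The step shows that this one substitution, phenyl to 4-methoxyphenyl, brings no difference that can be told from the scatter, although a single methoxy says nothing about other groups at this place, and no supporting data bear on why the outcome is as it is.

The compounds shown leave open whether an amine, a carboxylic acid or a longer chain such as butoxy on the same aromatic carbon would give a step beyond the scatter. They also leave open how the shared core would read with the same methoxy moved to another carbon of this ring, so a single step cannot yet describe the ring as a whole.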